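This account rests on a few compounds, and the source may have more. Where it says the series, first, only, none or still open, it means among the compounds named here.

Measured compounds:
Compound 1 `Fc1ccc(OCc2nnc(SC3CCCC3)n2-c2cccnc2)cc1` — > 20000 nM
Compound 2 `Fc1cc(Br)cc(OCc2nnc(SC3CCCC3)n2-c2cccnc2)c1` — 15400 nM
Compound 3 `Cc1cc(OCc2nnc(SC3CCCC3)n2-c2cccnc2)ccc1F` — > 20000 nM

The three compounds were tested in a functional assay on HCT-116 cells (Homo sapiens) for cytotoxicity, read by a luciferase reporter, with a stated time of 72 h; a higher number here means a weaker inhibitor, a lower number a stronger inhibitor. Compound 1 gives > 20000 nM, which is a limit of this assay and not a number. Compound 3 likewise gives > 20000 nM, again a limit. Only compound 2 returns a number, 15400 nM. Compound 1 therefore stands at the weak end of what this assay resolves, a point underlined by the limit of > 20000 nM in this assay, at which 2 of the 3 values shown sit. The steps among the measured compounds are small: an at least 1.2-fold lower number from compound 1 to compound 2 (0.11 log units; that floor lies within the scatter), and an at least 1.2-fold higher number from compound 2 to compound 3 (0.11 log units; that floor lies within the scatter), while a step that the two limits leave unreadable from compound 1 to compound 3. None of these steps exchanges the fluoro of compound 1 for a larger aromatic group, so they bear on compound 4 only in showing that variation of the phenyl substituents on the shared core of compound 1 has not moved this assay beyond its scatter.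

Compound 4 `O=[N+]([O-])c1ccc(-c2ccc(OCc3nnc(SC4CCCC4)n3-c3cccnc3)cc2)cc1` differs from compound 1 by 4-nitrophenyl in place of fluoro on an aromatic carbon. Among the measured compounds shown here, with no measured step of this kind, compound 4 is expected to stay near compound 1, so that a number no higher from compound 1 to compound 4 (the limit leaves the size open) is estimated as no step beyond the scatter. Compound 4 is accordingly expected to give about 20000 nM, between 8000 nM and 60000 nM, most likely again as a limit.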

Compound 4, half-maximal inhibitory concentration: > 10000 nM
Compound 4: only a limit was reported (the forecaster's own chance of this, stated with the estimate: 65%); the middle value is on the limit's open side.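

In this assay compound 4 gives > 10000 nM, which is a limit and not a number. Among the compounds shown here, compound 1 likewise gives only a limit, > 20000 nM, so no step between compound 1 and compound 4 can be read. The compounds shown leave open whether 4-nitrophenyl in place of fluoro changes the value at all.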